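From Chloro to Bromo on an Aromatic Carbon

The source may report more compounds than this note shows. Statements on the series, on what has been measured and on what is new or still open speak of the compounds shown alone.

In a functional assay on P388 cells (Mus musculus) for inhibition (on this read-out lower numbers stand for stronger inhibition and higher numbers for weaker inhibition), compound 3 `O=C1/C(=C/c2ccc(Cl)cc2)CCCc2ccccc21` gives 9500 nM and compound 2 `O=C1/C(=C/c2ccc(F)cc2)CCCc2ccccc21` gives 11100 nM so the two stand level within the scatter. Within the data shown here, compound 1 `O=C1/C(=C/c2ccc(Br)cc2)Cc2ccccc21` reports only a limit of the assay (> 50000 nM) and its core differs, so it offers no step here. Among the measured compounds shown here, compound 4 `O=C1/C(=C/c2ccc(Br)cc2)CCCc2ccccc21` carries bromo in place of chloro on an aromatic carbon and the one measured step that bears on this is chloro in place of fluoro on an aromatic carbon (a 1.2-fold lower number from compound 2 to compound 3 (0.07 log units; within the scatter)). That step was small, so no step beyond the scatter is expected in this assay for this swap. The expected change is slight (a 1.1-fold lower number from compound 3 to compound 4 (0.02 log units; within the scatter)). For compound 4 the estimated value is 9000 nM with an expected range from 4500 nM to 20000 nM in this measurement.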

Compound 4, half-maximal inhibitory concentration: 18600 nM
Beside the measured number, compound 4's estimate is 2.1-fold (0.32 log units) below it; measured number inside the range.
By their numbers in this assay, from the lowest: compounds 3, 2 and 4 (each within the scatter of the next). At a limit, above all of these: compound 1.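

Bromo joins fluoro and chloro at this position without leaving the scatter in this assay (a 2.0-fold higher number from compound 3 to compound 4 (0.29 log units; within the scatter); a 1.7-fold higher number from compound 2 to compound 4 (0.22 log units; within the scatter)). Until now only two halogens could be compared, so compound 4 extends the level picture to all three on this aromatic carbon, para to a large group. Nothing measured here gives a reason for this result.

Still open, from the compounds shown here alone, is whether a group other than a halogen, such as an amine, a methoxy group or a carboxylic acid, would change the number at this position.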